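Para substituent removal on the benzylamide phenyl ring

The compounds below may be only part of what the source reports. "The series", "measured", "known", "first", "only" and "open" are said of these compounds alone.

Measured so far:
compound 1 `CNC(=O)c1ccc(CN(C)C(=O)c2cc(Cl)c(O)cc2O)cc1` 34800 nM
compound 2 `O=C(NCc1ccccc1)c1cc(Cl)c(O)cc1O` 86200 nM
compound 3 `COc1ccc(CN(C)C(=O)c2cc(Cl)c(O)cc2O)cc1` 16700 nM

In a functional assay on NCI-H1975 cells (Homo sapiens) for antiproliferative activity, with a stated time of 72 h (a higher number here means a weaker inhibitor of growth, a lower number a stronger inhibitor of growth), compound 3 gives the lowest of the three numbers; compound 1 sits a step away, as a 2.1-fold lower number from compound 1 to compound 3 (0.32 log units; beyond the scatter) shows, and compound 2 lies further off. Compound 4 `CN(Cc1ccccc1)C(=O)c1cc(Cl)c(O)cc1O` differs from compound 3 by hydrogen in place of methoxy on an aromatic carbon. For the measured compounds named here, no measured step removes a group from this aromatic carbon; the only step touching that position, a 2.1-fold lower number from compound 1 to compound 3 (0.32 log units; beyond the scatter), swapped one substituent for another and was modest. Compound 2, which also carries an unsubstituted ring but lacks the methyl on the amide nitrogen, gives the highest number. A modest rise is therefore expected for compound 4, as a 1.9-fold higher number from compound 3 to compound 4 (0.28 log units; within the scatter). Compound 4 is estimated at 32000 nM, within 12000 nM to 85000 nM.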

Compound 4, concentration for 50% growth inhibition: 35500 nM
For compound 4 the middle estimate is 1.1-fold (0.05 log units) below the measured one; the measured number falls inside the stated range.
By their numbers in this assay, from the lowest: compound 3; then compounds 1 and 4 (each within the scatter of the next); then compound 2.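

Replacing methoxy with hydrogen at this aromatic carbon weakens growth inhibition modestly in this assay, with a 2.1-fold higher number from compound 3 to compound 4 (0.33 log units; beyond the scatter). Hydrogen and methylcarbamoyl here cannot be told apart, with a 1.0-fold higher number from compound 1 to compound 4 (0.01 log units; within the scatter), so of the three groups only methoxy separates from the others, while the methyl on the amide-type nitrogen also counts, with a 2.4-fold lower number from compound 2 to compound 4 (0.39 log units; beyond the scatter). No measurement at hand explains these steps.

Open, from the compounds shown here alone, is whether an amine, a carboxylic acid or ethoxy at this carbon would go beyond methoxy. Also open, going by these compounds, is whether the methyl on the nitrogen counts equally when methoxy is present.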